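This account rests on a few compounds, and the source may have more. Where it says the series, first, only, none or still open, it means among the compounds named here.

Measured so far:
Compound 1, `Oc1cccc(NCC2=NCCN2)c1`: 61 nM
Compound 2, `Cc1ccc(N(C)CC2=NCCN2)cc1`: 300 nM

In a functional assay for agonist activity at Adrenergic receptor alpha-1 (Rattus norvegicus) (a higher number here means that more compound is needed for the effect, a lower number that less compound is needed), compound 2 gives the highest of the two numbers; compound 1 sits lower by a gap beyond the usual scatter. Compound 3, `Cc1ccc(N(CC2=NCCN2)C2CCCCC2)cc1`, differs from compound 2 by cyclohexyl in place of methyl on a nitrogen on an aromatic ring. Going by the values given here, no measured pair shows this kind of change, so the direction rests on judgement alone; a step upward beyond the scatter is expected, meaning more compound needed. The step of a 3.3-fold higher number from compound 2 to compound 3 (0.52 log units; beyond the scatter) is the expected size. Compound 3 is estimated at 1000 nM, within 300 nM to 4000 nM.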

Compound 3, half-maximal effective concentration: > 10000 nM
Compound 3: only a limit was reported (the forecaster's own chance of this, stated with the estimate: 15%); middle value at least 10-fold (1.00 log units) from the limit.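

Swapping methyl for cyclohexyl on this nitrogen on an aromatic ring is a costly change: in this assay it gives an at least 33-fold higher number from compound 2 to compound 3 (1.52 log units; beyond the scatter). Going by these compounds alone, compound 3 has a limit of the assay rather than a true number: the limit of > 10000 nM in this assay, at which 1 of the 3 values shown sits. This step therefore gives only a minimum size, and it is the first measured change at this nitrogen.

Ethyl or isopropyl on this nitrogen could show whether the number climbs gradually or abruptly between methyl and cyclohexyl. The compounds shown do not explain why the change has such a large effect.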